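A few compounds are considered here, and "the series" means these few. Any claim that something is new, unique, unknown or untested is made for them only; others in the source may bear on it.

Measured in an assay for inhibition of Alpha amylase (Homo sapiens), with a stated time of 10 min; on this read-out lower numbers stand for stronger inhibition and higher numbers for weaker inhibition:
compound 1, `Oc1c(Br)cc(Cl)cc1-c1nc2cc(Cl)ccc2[nH]1`, gives 2860 nM
compound 2, `COc1ccc(Br)c(-c2nc3cc(Cl)ccc3[nH]2)c1O`, gives 2210 nM
compound 3, `COc1ccc(Br)c(-c2nc3cc([N+](=O)[O-])ccc3[nH]2)c1O`, gives 2290 nM

Compound 2 and compound 3 share a core and differ in one place only, by nitro in place of chloro on an aromatic carbon. That change gave a 1.0-fold higher number from compound 2 to compound 3 (0.02 log units; within the scatter). Compound 1 carries a different core; how compound 1 and compound 2 differ is not broken down here. The number for compound 1 stands within the scatter of both compound 2 and compound 3, so the three measured compounds cannot be set in any order.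

Compound 4, `O=[N+]([O-])c1ccc2[nH]c(-c3cc(Cl)cc(Br)c3O)nc2c1`, has not yet been measured. Within the data shown here, it differs from compound 1 by nitro in place of chloro on an aromatic carbon, which is the same change, at the same place, as the one from compound 2 to compound 3. The step from compound 1 to compound 4 in this assay is expected to be a 1.0-fold higher number from compound 1 to compound 4 (0.01 log units; within the scatter), because a 1.0-fold higher number from compound 2 to compound 3 (0.02 log units; within the scatter) stayed within the scatter. Compound 4 is therefore estimated to give about 2900 nM in this assay, with a likely range from 1500 nM to 5800 nM. This expectation rests on a single measured pair.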

Compound 4, half-maximal inhibitory concentration: 2870 nM
For compound 4 the middle estimate is 1.0-fold (0.00 log units) above the measured one, and the stated range covers the measured number.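

In this assay, putting nitro in place of chloro on an aromatic carbon of the core of compound 1 gave a 1.0-fold higher number from compound 1 to compound 4 (0.00 log units; within the scatter). Set beside the earlier case, the same change gave matching results on the two cores, with no difference between the steps beyond the scatter: the same change on two cores in this assay, a 1.0-fold higher number (0.02 log units; within the scatter) from compound 2 to compound 3 and a 1.0-fold higher number (0.00 log units; within the scatter) from compound 1 to compound 4, 1.0-fold (0.01 log units) apart, within the scatter of two such steps

This shows that, on these two cores, chloro and nitro at this place could be exchanged with no step beyond the scatter, but it does not show that the same would hold on any other core, and with neither step of measurable size, it cannot show whether a larger effect would carry over from one core to another.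

The compounds shown leave open what an amine or a carboxylic acid at this place would give in this assay. They also leave open whether the exchange of chloro for nitro would behave the same way on a core without the bromo group.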